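The source may hold more compounds than are shown below. What is called first, only, known or untested is meant among the compounds shown, and "the series" means these compounds.

Compound 1 `Oc1cccc(NC(=S)Nc2ccc3[nH]ccc3c2)c1` gives 81.4% in an ADME assay on isolated protein for inhibition of peroxidase (Raphanus sativus), read by fluorescence and Amplex Red, tested at 5 uM; a higher number here means a weaker effect of the compound at the concentration tested, a lower number a stronger effect; compound 2 `OCc1ccc(NC(=S)Nc2ccc3[nH]ccc3c2)cc1` gives 88.3%; compound 3 `S=C(Nc1ccc(Oc2ccccc2)cc1)Nc1ccc2[nH]ccc2c1` gives 73.1%.

Compound 3 has the lowest of the three numbers, though its gap to compound 1 is within the scatter, while compound 2 sits clearly higher. Compound 4 `CCOC(=O)c1ccc(NC(=S)Nc2ccc3[nH]ccc3c2)cc1` differs from compound 3 in one place: ethoxycarbonyl in place of phenoxy on an aromatic carbon. Going by the values given here, the only measured step that touches this position is a number 15.2 percentage points lower from compound 2 to compound 3 (beyond the scatter), which followed the arrival of phenoxy. Its departure may undo part of that drop, but nothing measured shows what ethoxycarbonyl does here. A modest rise is therefore expected, a number 8.9 percentage points higher from compound 3 to compound 4 (within the scatter), with wide uncertainty. Compound 4 is estimated at 82%, in the range 68% to 95%.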

Compound 4, a percentage reported as activity, at one concentration (the size of the read-out at that concentration, not a potency): 65.8%
Compound 4: middle estimate off by 16.2 percentage points, on the high side; measured number below the stated range.
By their numbers in this assay, from the lowest: compounds 4, 3, 1 and 2 (each within the scatter of the next, the first and the last beyond it).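

Losing the phenoxy ring costs nothing measurable at this position: ethoxycarbonyl in its place gives a number 7.3 percentage points lower from compound 3 to compound 4 (within the scatter) in this assay and carries no ring at all. The same group also gives a number 22.5 percentage points lower from compound 2 to compound 4 (beyond the scatter), so a clear drop from the hydroxymethyl compound does not depend on having phenoxy on that aromatic carbon. No measurement here explains why these groups give the numbers they do. Still open, as far as these compounds go, is how a carboxylic acid, an amine or a longer ester chain at this position would read, and whether any group could go clearly lower than ethoxycarbonyl and phenoxy.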